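From a Ring Amine to an Open-Chain Amine in Compound 4

The source may hold more compounds than are shown below. What is called first, only, known or untested is meant among the compounds shown, and "the series" means these compounds.

Compound 1 `Cc1ccc2c(=O)c(CSC(=S)N3CCCCC3)coc2c1` was tested in a functional assay on LM7 cells (Homo sapiens) for antiproliferative activity, read by MTT assay, with a stated time of 72 h (a lower number here means a stronger inhibitor, a higher number a weaker inhibitor), where compound 1 gives 5100 nM. Among the three compounds measured, that number is the second highest. Compound 2 `O=c1c(SC(=S)N2CCCCC2)coc2ccccc12` gives 7800 nM in this assay, which lies within the scatter of compound 1. Within the data shown here, compound 3 `O=c1c(CSC(=S)N2CCCCC2)coc2cc(Cl)ccc12` gives 850 nM in this assay, and the step of a 6.0-fold lower number from compound 1 to compound 3 (0.78 log units; beyond the scatter) is the only change between measured compounds that differs in a single place.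

Compound 4 `Cc1ccc2c(=O)c(CSC(=S)N(C(C)C)C(C)C)coc2c1` is not yet measured. It differs from compound 1 by diisopropylamino in place of piperidin-1-yl on a thiocarbonyl carbon. Among the measured compounds shown here, none of the measured steps touches this part of the molecule: the step from compound 1 to compound 3 concerns a substituent on an aromatic carbon, and compound 2 differs from compound 1 in more than one place, so its value shows only that it sits within the scatter of compound 1. There is therefore no measured guide for the exchange of the amine on the thiocarbonyl carbon, and no step beyond the scatter is expected in this assay.

On that basis compound 4 is estimated at 5500 nM, with a range from 1800 nM to 17000 nM, meaning an expected step of a 1.1-fold higher number from compound 1 to compound 4 (0.03 log units; within the scatter).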

Compound 4, half-maximal inhibitory concentration: 6300 nM
Compound 4: middle estimate off by 1.1-fold (0.06 log units), on the low side; low and high end bracket the measured number.
By their numbers in this assay, from the lowest: compound 3; then compounds 1, 4 and 2 (each within the scatter of the next).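

In this assay, among these compounds, the exchange on the thiocarbonyl carbon gives a 1.2-fold higher number from compound 1 to compound 4 (0.09 log units; within the scatter) and provides the first measured step at this position. In this one pair, the ring of piperidin-1-yl gives way to the open-chain diisopropylamino group, which has no ring, without a step beyond the scatter, whereas a 6.0-fold lower number from compound 1 to compound 3 (0.78 log units; beyond the scatter) at the aromatic carbon does go beyond it. The data offer no measured explanation for why the amine exchange leaves the number within the scatter.

The compounds shown leave open whether diisopropylamino would behave the same way alongside the chloro substituent of compound 3, the one compound whose number stands apart from the rest. They also do not show how this position would respond to other amines, such as morpholin-4-yl with its ring oxygen, the smaller open-chain dimethylamino group, or a piperazine ring bearing a second nitrogen.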